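The compounds below may be only part of what the source reports. "The series", "measured", "known", "first", "only" and "open" are said of these compounds alone.

Compound 1, `COc1cc(/C=C/C(C)=O)ccc1OCc1cn(-c2ccc(/N=N/c3ccccc3)cc2)nn1`, is tested in a functional assay on PC-3 cells (Homo sapiens) for antiproliferative activity, read by MTT assay, with a stated time of 48 h (on this read-out lower numbers stand for stronger inhibition and higher numbers for weaker inhibition), and gives 42100 nM. Among the three measured compounds it holds the highest number. Compound 2, `COc1cccc(-n2cc(COc3ccc(/C=C/C(C)=O)cc3OC)nn2)c1`, gives 31600 nM in this assay, and the two values lie within the scatter of each other. Compound 3, `COc1cc(/C=C/C(C)=O)ccc1OCc1cn(-c2ccccc2OC)nn1`, gives 2050 nM in this assay, and the gap from compound 1 to compound 3 lies beyond the scatter. For the measured compounds named here, the single measured step, a 15-fold lower number from compound 2 to compound 3 (1.19 log units; beyond the scatter), concerns the substituent on the aromatic nitrogen and shows that the group on this aromatic nitrogen can move the number far.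

Compound 4, `COc1cc(/C=C/C(C)=O)ccc1OCc1cn(-c2ccc(NC(=O)c3ccccc3)cc2)nn1`, differs from compound 1 by a group of 9 heavy atoms (7 carbon, 1 nitrogen, 1 oxygen; one six-membered aromatic ring of carbon only) in place of a group of 8 heavy atoms (6 carbon, 2 nitrogen; one six-membered aromatic ring of carbon only), on an aromatic carbon. Going by the values given here, no measured step bears directly on this exchange; only the step from compound 2 to compound 3 shows how much a change on the same aromatic nitrogen substituent can do, without fixing a direction. The step is therefore expected to be a 1.7-fold lower number from compound 1 to compound 4 (0.23 log units; within the scatter), with wide uncertainty. Compound 4 is estimated at 25000 nM, with a range from 6000 nM to 100000 nM.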

Compound 4, half-maximal inhibitory concentration: 76800 nM
Estimate against measurement, compound 4: 3.1-fold (0.49 log units) below; the measured number falls inside the stated range.
By their numbers in this assay, from the lowest: compound 3; then compounds 2, 1 and 4 (each within the scatter of the next, the first and the last beyond it).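

In this assay, benzamido in place of the group of 8 heavy atoms, on an aromatic carbon para to a large group, gives a 1.8-fold higher number from compound 1 to compound 4 (0.26 log units; within the scatter), so this exchange does not separate the two compounds. The earlier step, a 15-fold lower number from compound 2 to compound 3 (1.19 log units; beyond the scatter), showed that a change on the aromatic nitrogen substituent can move the number far, whereas this exchange of one large group for another, with a hydrogen-bond donor entering, leaves it within the scatter. No measurement shown here offers an explanation for this result.

As far as these compounds go, whether an amine or a carboxylic acid on this aromatic carbon would leave the number in the same range stays open. From the compounds shown here alone, it is also open whether any group at this place can bring the number near that of compound 3, at 2050 nM.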